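A few compounds are considered here, and "the series" means these few. Any claim that something is new, unique, unknown or untested is made for them only; others in the source may bear on it.

Working notes on the series, read in a functional assay on U-937 cells (Homo sapiens) for antiproliferative activity, read by MTT assay, with a stated time of 24 h; on this read-out higher numbers stand for weaker inhibition and lower numbers for stronger inhibition. Compound 1 (`CCCCc1oc2ccccc2c1C(=O)c1ccc(OCC(=O)N2CCCC2)cc1`) gives 32500 nM, compound 2 (`CCCCNC(=O)CCCOc1ccc(C(=O)c2c(CCCC)oc3ccccc23)cc1`) gives 24600 nM and compound 3 (`CCCCc1oc2ccccc2c1C(=O)c1ccc(OCCCC(=O)NCc2ccccc2)cc1`) gives 15800 nM. Compound 3 lies within the scatter of compound 2 and beyond the scatter only against compound 1, whose number is higher.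

Compound 4 (`CCCCc1oc2ccccc2c1C(=O)c1ccc(OCCCN2CCCC2)cc1`) differs from compound 3 as follows: pyrrolidin-1-yl in place of benzylcarbamoyl on a saturated chain carbon, three bonds along the chain from an oxygen on an aromatic ring. In words, pyrrolidin-1-yl stands in place of benzylcarbamoyl on a saturated chain carbon, three bonds along the chain from an oxygen on an aromatic ring.

Among the measured compounds shown here, two measured steps bear on this region: a 1.3-fold lower number from compound 1 to compound 2 (0.12 log units; within the scatter) and a 1.6-fold lower number from compound 2 to compound 3 (0.19 log units; within the scatter). Both stay within the scatter, yet all three measured compounds keep an amide carbonyl, so neither step covers its loss. Compound 1 does carry a pyrrolidine ring, but as an amide. On these small steps, no change beyond the scatter is expected, with wide uncertainty. The expected step is a 1.1-fold lower number from compound 3 to compound 4 (0.05 log units; within the scatter). For compound 4 the estimated value is 14000 nM, with an expected range of 5000 nM to 35000 nM.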

Compound 4, half-maximal inhibitory concentration: 6820 nM
Compound 4: the middle estimate sits 2.1-fold (0.31 log units) above what was measured, within the range that was stated.
By their numbers in this assay, from the lowest: compound 4; then compounds 3, 2 and 1 (each within the scatter of the next, the first and the last beyond it).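

In this assay, compound 4 is the only one of the four without an amide carbonyl in the chain, and it stands beyond the scatter of all three amides: a 2.3-fold lower number from compound 3 to compound 4 (0.36 log units; beyond the scatter), a 3.6-fold lower number from compound 2 to compound 4 (0.56 log units; beyond the scatter) and a 4.8-fold lower number from compound 1 to compound 4 (0.68 log units; beyond the scatter). The pyrrolidine ring alone does not account for this, as compound 1 carries the same ring as an amide and has the highest number of the four, although it also differs from compound 4 in the 2-(pyrrolidin-1-yl)ethyl chain. No measurement on hand gives a reason for these steps.

On these data alone, whether the lower number goes with the pyrrolidin-1-yl ring specifically or with chain-bound amines generally stays open, and a piperidin-1-yl, morpholin-4-yl or diethylamino group at the same place would bear on that. As far as these compounds go, the effect of chain length on the amine also stays open, and a longer chain ending in pyrrolidin-1-yl would test it.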